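Removing one chloro from the shared core

This account rests on a few compounds, and the source may have more. Where it says the series, first, only, none or still open, it means among the compounds named here.

Measured compounds:
compound 1 `ClCc1ccc(Cn2cnc3nc(Cl)nc(Cl)c32)cc1` — 1900 nM
compound 2 `ClCc1cccc(Cn2cnc3c(Cl)nc(Cl)nc32)c1` — 1730 nM

Of the compounds shown here, two have been tested in a functional assay on EKVX cells (Homo sapiens) for cytotoxicity, read by sulforhodamine B assay, with a stated time of 48 h; on this read-out higher numbers stand for weaker inhibition of growth and lower numbers for stronger inhibition of growth. Compound 1 gives 1900 nM, the highest of the two numbers, and compound 2 gives 1730 nM; the two values sit within the scatter of each other, so neither can be called the stronger inhibitor of growth. For the measured compounds named here, no step between measured compounds that differ in a single place is available.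

Compound 3 `ClCc1ccc(Cn2cnc3ncnc(Cl)c32)cc1` has not yet been tested in this assay. It differs from compound 1 in one place: hydrogen in place of chloro on an aromatic carbon, the hydrogen entering between two ring nitrogen atoms on the six-membered ring of the shared core, with the remaining chloro group left in place.

Going by the values given here, with no measured step of this kind to lean on, the size of the expected change rests on the nature of the change alone. Removing a chloro group is expected to leave the number about where it is or move it modestly upward, towards weaker inhibition of growth, rather than downward; the expected step is a 1.6-fold higher number from compound 1 to compound 3 (0.20 log units; within the scatter). Compound 3 is therefore estimated at 3000 nM, with a range from 1000 nM to 10000 nM.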

Compound 3, concentration for 50% growth inhibition: 2230 nM
Compound 3: the middle estimate sits 1.3-fold (0.13 log units) above what was measured; the range from low to high includes it.
By their numbers in this assay, from the lowest: compounds 2, 1 and 3 (each within the scatter of the next).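

In this assay, for the compounds shown here, hydrogen in place of chloro on the aromatic carbon between two ring nitrogen atoms gives a 1.2-fold higher number from compound 1 to compound 3 (0.07 log units; within the scatter), the first step in this set that changes a single place. It shows that, with the other chloro group left in place, this chloro group can be exchanged for hydrogen with no change beyond the scatter, so the number at this position does not depend measurably on that one chloro group in this pair. The data offer no measured basis for explaining this result.

The compounds shown leave open whether a larger or different group on this same carbon, such as an amine, a methoxy group or a thioether, would move the number beyond the scatter, since a single exchange for hydrogen tests only the loss of chloro. They also leave open what would follow if the remaining chloro group of compound 3 gave way to hydrogen or an amine, or if a methyl or hydroxymethyl group stood in place of the chloromethyl group.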